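Compound 4: adding 5-(nitrooxy)pentyl on the aromatic oxygen

A few compounds are considered here, and "the series" means these few. Any claim that something is new, unique, unknown or untested is made for them only; others in the source may bear on it.

In a functional assay on NCI-H157 cells (Homo sapiens) for cytotoxicity, read by resazurin assay, with a stated time of 72 h (on this read-out lower numbers stand for stronger inhibition and higher numbers for weaker inhibition), compound 2 `COc1cc(/C=C/C(=O)OCCCCCO[N+](=O)[O-])ccc1O` gives 13400 nM, and compound 3 `COc1cc(/C=C/C(=O)OCCCO[N+](=O)[O-])ccc1O` gives 20500 nM. Among the compounds with values here, the only measured step, a 1.5-fold higher number from compound 2 to compound 3 (0.18 log units; within the scatter), sits on a saturated chain carbon, so it says little about the change considered here. Compound 4 `COc1cc(/C=C/C(=O)OCCCCCO[N+](=O)[O-])ccc1OCCCCCO[N+](=O)[O-]` differs from compound 2 by 5-(nitrooxy)pentyl in place of hydrogen on an oxygen on an aromatic ring, with 5-(nitrooxy)pentyl in place of hydrogen on an oxygen on an aromatic ring. Compound 1 `O=C(/C=C/c1ccc(OCCCCCO[N+](=O)[O-])c(O)c1)OCCCCCO[N+](=O)[O-]` also bears that group on such an oxygen. With compound 1 at > 50000 nM, an assay limit, a higher number and so weaker inhibition is expected for compound 4. The estimated step is a 2.4-fold higher number from compound 2 to compound 4 (0.38 log units; beyond the scatter). Compound 4 is expected at 32000 nM, within an estimated range of 15000 nM to 50000 nM.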

Compound 4, half-maximal inhibitory concentration: > 50000 nM
Compound 4 ended at the assay's limit; the forecaster's own chance of this, stated with the estimate: 35%; middle value at least 1.5-fold (0.19 log units) away from the limit.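

Within the data shown here, putting 5-(nitrooxy)pentyl on the aromatic oxygen of compound 2 gives the first step beyond the scatter in this assay: an at least 3.7-fold higher number from compound 2 to compound 4 (0.57 log units; beyond the scatter). That step is only a lower bound, since compound 4 sits at an assay limit, the same one that applies to compound 1: the limit of > 50000 nM in this assay, at which 2 of the 4 values shown sit.

The step between compound 1 and compound 4 cannot be read, so methyl in place of hydrogen on the aromatic oxygen remains unresolved. Also open, going by these compounds, is whether a chain ending in an amine or a carboxylic acid on this oxygen would retain the activity of compound 2.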